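The compounds below may be only part of what the source reports. "The series", "measured", "known", "first", "only" and "open" are said of these compounds alone.

Compound 1 `O=C1C=C(NCc2ccccc2)C(=O)c2c1nc1n2[C@H]2OC[C@@H](O)[C@H]2OC1`: > 8000 nM, a limit of the assay and not a number
Compound 2 `O=C1C(Nc2ccccc2F)=CC(=O)c2c1nc1n2[C@H]2OC[C@@H](O)[C@H]2OC1`: 2660 nM
Compound 3 `O=C1C=C(Nc2ccccc2F)C(=O)c2c1nc1n2[C@H]2OC[C@@H](O)[C@H]2OC1`: 2760 nM

All three were tested in a functional assay on ECa-109 cells for inhibition, with ECa-109 cell line (Homo sapiens) as the target, read by sulforhodamine B assay; on this read-out lower numbers stand for stronger inhibition and higher numbers for weaker inhibition. Compound 2 lies within the usual scatter of compound 3, so neither can be ranked above the other. Only these two give true numbers, which leaves compound 2 with a single close neighbour.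

The next compound is compound 4 `Cc1ccc(NC2=CC(=O)c3c(nc4n3[C@H]3OC[C@@H](O)[C@H]3OC4)C2=O)cc1`. Its difference from compound 2 is 4-methylphenyl in place of 2-fluorophenyl on an amine nitrogen.

For the measured compounds named here, only one measured step changes the group on such a nitrogen: an at least 2.8-fold lower number from compound 1 to compound 3 (0.46 log units; beyond the scatter). There, 2-fluorophenyl replaces benzyl, so it offers only indirect guidance. Going by the values given here, no measured step compares 2-fluorophenyl with 4-methylphenyl. Compound 4 keeps a phenyl ring rather than benzyl, so no shift beyond the scatter is expected, though the uncertainty is wide.

The expected change is a 1.1-fold lower number from compound 2 to compound 4 (0.03 log units; within the scatter). For compound 4 the estimated value is 2500 nM, with an expected range from 800 nM to 7000 nM.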

Compound 4, half-maximal inhibitory concentration: > 4000 nM
Compound 4: no number, only a limit; the forecaster's own chance of this, stated with the estimate: 15%; middle value at least 1.6-fold (0.20 log units) from the limit.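

For the compounds shown here, compounds 2 and 4 give the first comparison of two substituted phenyl groups on this amine nitrogen, since the earlier step set a phenyl group only against benzyl. In this assay, the change reads as an at least 1.5-fold higher number from compound 2 to compound 4 (0.17 log units; that floor lies within the scatter), so 4-methylphenyl brings no gain over 2-fluorophenyl at this position. Compound 4 has only a limit of the assay and not a number, and the true size of the step stays unknown because the reading stops there: the limit of > 4000 nM in this assay, at which 1 of the 4 values shown sits.

This swap alters both the atom on the ring and its place, so the two effects cannot be told apart. From the compounds shown here alone, whether 2-methylphenyl, 4-fluorophenyl or plain phenyl on the same nitrogen would come closer to compound 2 remains open.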